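Methoxy for methyl on the pendant aryl of a tricyclic series

The source may report more compounds than this note shows. Statements on the series, on what has been measured and on what is new or still open speak of the compounds shown alone.

For the measured compounds named here, compound 1 `CCCCN(CC)c1cc(C)nc2c1NC(=O)CN2c1ccc(C)cc1C` gives the lower of the two numbers so far in an assay on HEK-293T cells for displacement of a labelled ligand from corticotropin-releasing factor receptor 1 (Homo sapiens), read by scintillation counting, with a stated time of 2 h (on this read-out lower numbers stand for stronger inhibition and higher numbers for weaker inhibition), at 3.9 nM. Compound 2 `CCN(C)c1cc(C)nc2c1NC(=O)CN2c1ccc(C(C)C)cc1Br` shares the core but carries other groups on both the amine and the aryl ring; in this assay compound 2 gives 16.4 nM, a weaker value than that of compound 1, and the gap between the two lies beyond the usual scatter. The two compounds differ in several places at once, so no single change can be read from this pair.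

Compound 3 `CCCCN(CC)c1cc(C)nc2c1NC(=O)CN2c1ccc(OC)cc1C` keeps the amine and the core of compound 1 and changes only the aryl ring: methoxy in place of methyl on an aromatic carbon. Going by the values given here, no measured pair in this set isolates such a change, so the size of the step in this assay has no direct precedent. Compound 3 is expected to stay close to compound 1, with a step of a 1.4-fold higher number from compound 1 to compound 3 (0.15 log units; within the scatter) that may fall within the scatter. The estimate for compound 3 in this assay is 5.5 nM, with a range from 2 nM to 16 nM.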

Compound 3, inhibition constant: 4 nM
Estimate against measurement, compound 3: 1.4-fold (0.14 log units) above; low and high end bracket the measured number.
By their numbers in this assay, from the lowest: compounds 1 and 3 (each within the scatter of the next); then compound 2.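

In this assay, for the compounds shown here, replacing the methyl of compound 1 with the methoxy of compound 3, on the aromatic carbon meta to a methyl group and para to a large group, gives a 1.0-fold higher number from compound 1 to compound 3 (0.01 log units; within the scatter) and provides the first single-place step. At this position on this scaffold, the 2,4-dimethylphenyl and 4-methoxy-2-methylphenyl groups therefore cannot be told apart by this read-out, even with one more heavy atom and one hydrogen-bond acceptor in the entering group. No measurement at hand accounts for this equivalence.

Open, from the compounds shown here alone, is whether an ethoxy group, a nitrile or a carboxylic acid on this carbon would read the same way. Also open, going by these compounds, is whether the methyl-to-methoxy step carries over to the ethyl(methyl)amino group of compound 2, whose aryl ring differs as well.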